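One side group changed on a shared core

The source may report more compounds than this note shows. Statements on the series, on what has been measured and on what is new or still open speak of the compounds shown alone.

Measured in a functional assay on MGC-803 cells (Homo sapiens) for antiproliferative activity, read by MTT assay, with a stated time of 48 h; a lower number here means a stronger inhibitor, a higher number a weaker inhibitor:
- compound 1 `COc1ccc(CN(C(=O)Cn2cc(COc3cc(=O)oc4ccccc34)nn2)c2cc(OC)c(OC)c(OC)c2)cc1`: 3660 nM
- compound 2 `COc1ccc(CN(C(=O)Cn2cc(CSc3nc4ccccc4o3)nn2)c2cc(OC)c(OC)c(OC)c2)cc1`: 1850 nM

Compound 2 and compound 1 sit within the scatter of each other, so neither ranks above the other. Compound 3 `COc1ccc(CN(C(=O)Cn2cc(Cn3ccc4ccccc43)nn2)c2cc(OC)c(OC)c(OC)c2)cc1` carries a new group at the same place: 1H-indol-1-yl in place of (1,3-benzoxazol-2-yl)sulfanyl on a saturated chain carbon bound to an aromatic carbon. Here 1H-indol-1-yl stands in place of (1,3-benzoxazol-2-yl)sulfanyl on a saturated chain carbon bound to an aromatic carbon. Going by the values given here, the only guide is the earlier swap at that place, a 2.0-fold lower number from compound 1 to compound 2 (0.30 log units; within the scatter), which lies within the scatter. No step beyond the scatter is therefore expected in this assay, though a single step is thin evidence and the range stays wide. The expected step is a 1.1-fold higher number from compound 2 to compound 3 (0.03 log units; within the scatter). For compound 3 the estimated value is 2000 nM, with an expected range of 600 nM to 6500 nM.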

Compound 3, half-maximal inhibitory concentration: 42600 nM
The estimate for compound 3 lay 21-fold (1.33 log units) below the measured number; the measured number lies above the stated range.
By their numbers in this assay, from the lowest: compounds 2 and 1 (each within the scatter of the next); then compound 3.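

In this assay, this place on the shared core proves sensitive to the group it carries: 1H-indol-1-yl brings a clear loss against both earlier groups (a 23-fold higher number from compound 2 to compound 3 (1.36 log units; beyond the scatter)) and (a 12-fold higher number from compound 1 to compound 3 (1.07 log units; beyond the scatter)). The earlier swap between compound 1 and compound 2 stayed within the scatter, but that tolerance does not extend to every two-ring group. Nothing measured here explains the loss.

Still open, as far as these compounds go, is whether the loss comes from the ring itself or from losing the sulfur link. How an amine, a carboxylic acid or a longer chain would fare at this place is also unknown.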